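Replacing the 6-methylpyridin-3-yl group of compound 1

The compounds below may be only part of what the source reports. "The series", "measured", "known", "first", "only" and "open" are said of these compounds alone.

Within the data shown here, in a physicochemical assay for solubility, read by nephelometry, in phosphate buffer, measured as kinetic solubility, with a stated time of 30 min, at pH 6.5 (a lower number here means a less soluble compound, a higher number a more soluble compound), compound 1 `Cc1ccc(-c2cc(-c3ccc(S(C)(=O)=O)cc3)cnc2N)cn1` gives 50 ug/mL, the higher of the two numbers measured so far, and compound 2 `Cc1ccc(-c2cc(-c3ccc(S(C)(=O)=O)cc3)cnc2N)cc1C(F)(F)F` gives 1.6 ug/mL, a gap beyond the scatter. Compound 3 `CS(=O)(=O)c1ccc(-c2cnc(N)c(-c3ccc(C#N)cc3)c2)cc1` has 4-cyanophenyl in place of the 6-methylpyridin-3-yl of compound 1 on an aromatic carbon (4-cyanophenyl in place of 6-methylpyridin-3-yl on an aromatic carbon). Among the measured compounds shown here, no measured pair shows this change directly. For the measured compounds named here, the only guide is compound 2 at 1.6 ug/mL, which also lacks the 6-methylpyridin-3-yl group. A fall beyond the scatter is therefore expected in this assay, an estimated 8.3-fold lower number from compound 1 to compound 3 (0.92 log units; beyond the scatter). For compound 3 the estimated value is 6 ug/mL, with an expected range of 1.5 ug/mL to 20 ug/mL.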

Compound 3, solubility: 1.6 ug/mL
For compound 3 the middle estimate is 3.8-fold (0.57 log units) above the measured one, within the range that was stated.
By their numbers in this assay, from the lowest: compounds 2 and 3 (each within the scatter of the next); then compound 1.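

In this assay the change to 4-cyanophenyl on this aromatic carbon, ortho to an amino group, gives a 31-fold lower number from compound 1 to compound 3 (1.49 log units; beyond the scatter) as a direct reading. Compound 3 at 1.6 ug/mL and compound 2 at 1.6 ug/mL lie within the scatter of each other, so these two replacements of 6-methylpyridin-3-yl cannot be told apart here. Nothing measured on these compounds accounts for the step. Still open, on these data alone, is whether an amine or a carboxylic acid in place of the nitrile would change the number of compound 3. Also open, as far as these compounds go, is whether another nitrogen-containing ring, such as unsubstituted pyridin-3-yl, would stay close to compound 1.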